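From Trifluoromethyl to Methoxy: Estimating Compound 3

The compounds below may be only part of what the source reports. "The series", "measured", "known", "first", "only" and "open" are said of these compounds alone.

- compound 1 `COc1ccc(/C=C/C(=O)Nc2nnc(-c3ccc(Cl)cc3)s2)cc1` gives 1.38 ug/mL
- compound 2 `COc1ccc(-c2nnc(NC(=O)/C=C/c3ccc(C(F)(F)F)cc3)s2)cc1` gives 0.69 ug/mL

In a functional assay on A549 cells (Homo sapiens) for antiproliferative activity, read by MTT assay, with a stated time of 48 h (on this read-out lower numbers stand for stronger inhibition and higher numbers for weaker inhibition), compound 2 gives 0.69 ug/mL and compound 1 gives 1.38 ug/mL so the two lie within the usual scatter of each other and cannot be ranked. Among the compounds with values here, compound 3 `COc1ccc(/C=C/C(=O)Nc2nnc(-c3ccc(OC)cc3)s2)cc1` has methoxy in place of trifluoromethyl on an aromatic carbon, para to a large group, when set against compound 2 methoxy in place of trifluoromethyl on an aromatic carbon and no measured pair shows this change alone. Within the data shown here, the only guide is compound 1, which also carries methoxy in that place and gives 1.38 ug/mL in this assay as well. The expected step of a 1.7-fold higher number from compound 2 to compound 3 (0.24 log units; within the scatter) is small, a slight rise in the number that stays within the usual scatter. For compound 3 the estimated value is 1.2 ug/mL with an expected range from 0.4 ug/mL to 4 ug/mL in repeat measurements.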

Compound 3, half-maximal inhibitory concentration: 0.52 ug/mL
Compound 3: middle estimate off by 2.3-fold (0.36 log units), on the high side, within the range that was stated.
By their numbers in this assay, from the lowest: compounds 3, 2 and 1 (each within the scatter of the next, the first and the last beyond it).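

In this assay, methoxy in place of trifluoromethyl gives a 1.3-fold lower number from compound 2 to compound 3 (0.12 log units; within the scatter), so at this position the two groups cannot be told apart. Methoxy in place of chloro, on an aromatic carbon of the other carbon-only ring, gives a 2.7-fold lower number from compound 1 to compound 3 (0.42 log units; beyond the scatter), a modest step and the only one here beyond the scatter. Nothing in the data shown accounts for that step.

Going by these compounds, whether a small amine or a carboxylic acid on either ring would keep numbers this low remains open. So does whether the step from chloro to methoxy would hold on the ring that carried trifluoromethyl.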